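Chain length variation at the sulfonyl side of a catechol vinyl sulfone

The source may report more compounds than this note shows. Statements on the series, on what has been measured and on what is new or still open speak of the compounds shown alone.

Measured compounds:
compound 1, `O=S(=O)(/C=C/c1ccc(O)c(O)c1)CC1CCCCC1`, 7500 nM
compound 2, `C=CCCCCCCS(=O)(=O)/C=C/c1ccc(O)c(O)c1`, 6400 nM
compound 3, `O=S(=O)(/C=C/c1ccc(O)c(O)c1)CCC1CCCC1`, 6800 nM

All three share the catechol vinyl sulfone core and were tested in a functional assay, read by fluorescence and spectrophotometry, with a stated time of 1 h; a higher number here means that more compound is needed for the effect, a lower number that less compound is needed. The three values lie close together: the step of a 1.2-fold lower number from compound 1 to compound 2 (0.07 log units; within the scatter), the step of a 1.1-fold lower number from compound 1 to compound 3 (0.04 log units; within the scatter) and the step of a 1.1-fold higher number from compound 2 to compound 3 (0.03 log units; within the scatter) are each within the scatter, so compound 3 sits among numbers that cannot be told apart from one another.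

Compound 4, `O=S(=O)(/C=C/c1ccc(O)c(O)c1)CCCC1CCCC1`, has not yet been measured. It differs from compound 3 in one place: cyclopentylmethyl in place of cyclopentyl on a saturated chain carbon, two bonds along the chain from a sulfonyl sulfur. Of the measured steps, a 1.1-fold lower number from compound 1 to compound 3 (0.04 log units; within the scatter) and a 1.1-fold higher number from compound 2 to compound 3 (0.03 log units; within the scatter) bear on it most directly, as both alter the group on the saturated chain carbons bound to the sulfonyl sulfur, and neither moved the number beyond the scatter. Another lengthening of that chain by a single carbon is therefore expected to leave the read-out essentially unchanged, with the step of no change at the digits printed from compound 3 to compound 4 (within the scatter) anticipated to stay within the scatter. Compound 4 is estimated to give 6800 nM in this assay, expected to fall between 3500 nM and 13000 nM.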

Compound 4, half-maximal effective concentration: 6300 nM
Estimate against measurement, compound 4: 1.1-fold (0.03 log units) above; low and high end bracket the measured number.
By their numbers in this assay, from the lowest: compounds 4, 2, 3 and 1 (each within the scatter of the next).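

In this assay, placing cyclopentylmethyl where cyclopentyl stood, on a saturated chain carbon, two bonds along the chain from a sulfonyl sulfur, still does not move the number beyond the scatter (a 1.1-fold lower number from compound 3 to compound 4 (0.03 log units; within the scatter)). Compound 4 also cannot be told apart from the compounds carrying the open-chain hept-6-en-1-yl group (a 1.0-fold lower number from compound 2 to compound 4 (0.01 log units; within the scatter)) or the cyclohexyl group (a 1.2-fold lower number from compound 1 to compound 4 (0.08 log units; within the scatter)), so the four compounds form a single flat set with no trend in chain length. Nothing available accounts for this flatness.

The compounds shown leave open whether an amine or a carboxylic acid at the end of this chain would shift the number in this assay. They also leave open whether a much longer chain, or an aromatic phenyl ring in place of the saturated ring, would do so.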